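Swapping a hydroxyethyl amide for a methoxycyclohexyl amide

A few compounds are considered here, and "the series" means these few. Any claim that something is new, unique, unknown or untested is made for them only; others in the source may bear on it.

Of the compounds shown here, three have been measured in an ADME assay for permeability; on this read-out lower numbers stand for lower permeability and higher numbers for higher permeability. Compound 1 `CNC(=O)c1cc(C(=O)N[C@H]2CC[C@H](O)CC2)c([C@@H](C)c2ccc(Cl)cc2)o1` gives 150 nm/s, and compound 2 `CNC(=O)c1cc(C(=O)N[C@H]2CC[C@H](O)CC2)c([C@@H](C)c2cccc(OC)c2)o1`, which differs from it only in the aryl group, gives 44 nm/s; that change reads a 3.4-fold lower number from compound 1 to compound 2 (0.53 log units; beyond the scatter). Compound 3 `CNC(=O)c1cc(C(=O)NCCO)n([C@@H](C)c2ccccc2)n1`, built on a different core, gives 59 nm/s, which places it second highest of the three: its gap to compound 2 is within the scatter, while compound 1 lies beyond the scatter above it.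

Compound 4 `CNC(=O)c1cc(C(=O)N[C@H]2CC[C@H](OC)CC2)n([C@@H](C)c2ccccc2)n1` keeps the core of compound 3 and changes only the amide substituent: 4-methoxycyclohexyl in place of 2-hydroxyethyl on an amide-type nitrogen. Within the data shown here, no measured step covers this kind of change; the single step, from compound 1 to compound 2, concerns the aryl group and is on another core, so it offers no direct guide. Compounds 1 and 2 do show that amides carrying a six-membered carbon ring on this nitrogen can sit either above or near the value of compound 3.

Given that spread, compound 4 is expected to land somewhat higher than compound 3, by about a 2.0-fold higher number from compound 3 to compound 4 (0.31 log units; beyond the scatter), with wide uncertainty. The estimate for compound 4 in this assay is 120 nm/s, between 50 nm/s and 300 nm/s.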

Compound 4, apparent permeability: 360 nm/s
For compound 4 the middle estimate is 3.0-fold (0.48 log units) below the measured one, and the stated range ends below it.
By their numbers in this assay, from the lowest: compounds 2 and 3 (each within the scatter of the next); then compound 1; then compound 4.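

In this assay, the amide nitrogen on the core shared by compound 3 and compound 4 proves to be a place where a single change can move the number well past the scatter: 4-methoxycyclohexyl in place of 2-hydroxyethyl gives a 6.1-fold higher number from compound 3 to compound 4 (0.79 log units; beyond the scatter) on this core. Among these compounds, this is the first measured step at this position, as the earlier step concerned the aryl group on a different core. The swap alters several things at once, adding a six-membered carbon ring and two defined stereocentres and removing a hydrogen-bond donor, and nothing available here shows which of these lies behind the rise.

A 2-methoxyethyl group or a 4-hydroxycyclohexyl group on the core of compound 3 would help separate the part played by the ring from the part played by the methyl on the oxygen. Also open, going by these compounds, are how an amine or a carboxylic acid at the end of a longer chain on this nitrogen would read, and whether the same swap would give a similar step on the core of compound 1.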